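The compounds below may be only part of what the source reports. "The series", "measured", "known", "first", "only" and "open" are said of these compounds alone.

Measured so far:
compound 1, `Cc1cc(NC(=O)Nc2ccc(F)cc2)c2ccccc2n1`: > 25000 nM
compound 2, `Cc1cc(NC(=O)Nc2cccc(F)c2)c2ccccc2n1`: > 25000 nM
compound 3, `Cc1cc(NC(=O)Nc2cc(F)cc(F)c2)c2ccccc2n1`: > 25000 nM

All three compounds were tested in an ADME assay on Raji cells (Homo sapiens) for cytotoxicity, with a stated time of 72 h; on this read-out higher numbers stand for an effect only at larger amounts of compound and lower numbers for an effect already at smaller amounts. Compound 1 gives > 25000 nM, which is a limit of the assay and not a number. Compound 2 gives > 25000 nM, again a limit. Compound 3 gives > 25000 nM, also a limit. Because every value sits at the limit of > 25000 nM in this assay, at which 3 of the 3 values shown sit, neither the step that the two limits leave unreadable from compound 1 to compound 2 nor the step that the two limits leave unreadable from compound 2 to compound 3 can be read as a size. Compound 1 and compound 2 are built from the same atoms joined differently: 4-fluorophenyl in place of 3-fluorophenyl on an amide-type nitrogen. Compound 2 and compound 3 differ by fluoro in place of hydrogen on an aromatic carbon.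

Compound 4, `Cc1cc(NC(=O)Nc2ccc(F)cc2F)c2ccccc2n1`, has not yet been measured in this assay. It differs from compound 1 by fluoro in place of hydrogen on an aromatic carbon. Within the data shown here, this is the same kind of change as the one from compound 2 to compound 3, but not the same: in compound 4 the entering fluoro sits ortho to a large group and meta to a fluoro group, whereas in compound 3 it sits meta to a fluoro group and meta to a large group. The measured step of this kind is unreadable because both of its ends sit at the limit of > 25000 nM in this assay, at which 3 of the 3 values shown sit. The expectation for compound 4 therefore rests on compound 1 alone. The step that the limit leaves unreadable from compound 1 to compound 4 is expected to be small. In this assay compound 4 is estimated at 30000 nM, within a range from 20000 nM to 60000 nM, and most likely reported again only as a limit.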

Compound 4, half-maximal effective concentration: > 25000 nM
Compound 4 gave a limit, no number (the forecaster's own chance of this, stated with the estimate: 85%); the middle value is on the limit's open side.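

In this assay compound 4 gives > 25000 nM, which is a limit of the assay and not a number. The step from compound 1 to compound 4 therefore cannot be read as a size, because both ends sit at the same limit: the limit of > 25000 nM in this assay, at which 4 of the 4 values shown sit.

The compounds shown leave open whether compounds 1, 2, 3 and 4 differ from one another in cytotoxicity at all.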